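A few compounds are considered here, and "the series" means these few. Any claim that something is new, unique, unknown or untested is made for them only; others in the source may bear on it.

Compound 2 `CN1C[C@H](C(=O)Nc2ccc(C(F)(F)F)cc2)[C@@H](c2ccc(/C=C/C(=O)Nc3ccccc3N)cc2)C1` gives 23 mL/min/kg in an in vitro ADME assay on microsomes from liver (Mus musculus) for pharmacokinetics, read by LC-MS, with a stated time of 10 min, tested at 1 uM (a lower number here means slower removal, a higher number faster removal of the compound), the lower of the two numbers measured; compound 1 `COc1ccc(NC(=O)[C@H]2CN(C)C[C@@H]2c2ccc(/C=C/C(=O)Nc3ccccc3N)cc2)cc1` gives 54 mL/min/kg in this assay. Among the measured compounds shown here, the one measured step runs from compound 1 to compound 2 and reads a 2.3-fold lower number from compound 1 to compound 2 (0.37 log units; beyond the scatter). Compound 3 `CN1C[C@H](C(=O)Nc2ccc(F)c(Br)c2)[C@@H](c2ccc(/C=C/C(=O)Nc3ccccc3N)cc2)C1` differs from compound 2 by 3-bromo-4-fluorophenyl in place of 4-(trifluoromethyl)phenyl on an amide-type nitrogen, a swap on the amide-type nitrogen whose other neighbour is the carbonyl carbon. For the measured compounds named here, the measured step also changed the group on that nitrogen, so it bears on this change, but it swapped different groups, and no measured pair shows 3-bromo-4-fluorophenyl against 4-(trifluoromethyl)phenyl. Compound 3 is therefore expected to sit close to compound 2, with a step of a 1.3-fold higher number from compound 2 to compound 3 (0.12 log units; within the scatter) that is expected to stay within the scatter. The estimate for compound 3 in this assay is 30 mL/min/kg, with a range from 15 mL/min/kg to 60 mL/min/kg.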

Compound 3, clearance: 43 mL/min/kg
For compound 3 the middle estimate is 1.4-fold (0.16 log units) below the measured one; measured number inside the range.
By their numbers in this assay, from the lowest: compounds 2, 3 and 1 (each within the scatter of the next, the first and the last beyond it).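

In this assay, the group on the amide-type nitrogen changes again: 3-bromo-4-fluorophenyl in place of 4-(trifluoromethyl)phenyl gives a 1.9-fold higher number from compound 2 to compound 3 (0.27 log units; within the scatter), and 3-bromo-4-fluorophenyl in place of 4-methoxyphenyl gives a 1.3-fold lower number from compound 1 to compound 3 (0.10 log units; within the scatter). Both steps lie within the scatter, so compound 3 cannot be told apart from either neighbour, even though compounds 1 and 2 do differ beyond the scatter; a third aromatic group at this position thus adds no clear separation of its own. Nothing available explains these numbers.

The compounds shown do not separate the contributions of the bromine and the fluorine, since no phenyl carrying only one of them appears. They also leave open how this position responds to a pyridine ring or to a phenyl bearing a carboxylic acid.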